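The compounds below may be only part of what the source reports. "The series", "measured", "known", "first", "only" and "open" are said of these compounds alone.

Measured compounds in a toxicity assay on NIH3T3 cells (Mus musculus) for cytotoxicity, read by resazurin assay; on this read-out lower numbers stand for an effect already at smaller amounts and higher numbers for an effect only at larger amounts of compound:
Compound 1, `CC(C)OC(=O)c1ccc(NCc2cncn2Cc2ccc(-c3ccccc3)cc2)cc1-c1ccccc1`, gives > 10000 nM; this is a limit of the assay, not a number.
Compound 2, `c1ccc(-c2ccc(Cn3cncc3CNc3ccc(-c4ccccc4)c(-c4ccccc4)c3)cc2)cc1`, gives > 10000 nM, again a limit.
Compound 3, `CCC(=O)c1ccc(NCc2cncn2Cc2ccc(-c3ccccc3)cc2)cc1-c1ccccc1`, gives > 10000 nM, also a limit.

Among the measured compounds shown here, compound 2 thus stands at the limit shared by every measured compound, the one described by the limit of > 10000 nM in this assay, at which 3 of the 3 values shown sit; no measured compound yields a number in this assay. The steps among the measured compounds, a step that the two limits leave unreadable from compound 1 to compound 2, a step that the two limits leave unreadable from compound 1 to compound 3 and a step that the two limits leave unreadable from compound 2 to compound 3, are all unreadable, the two ends of each sitting at the limit of the limit of > 10000 nM in this assay, at which 3 of the 3 values shown sit. Their sizes and directions are therefore unknown.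

Compound 4, `c1ccc(-c2ccc(Cn3cncc3CNc3ccc(-c4ccccc4)cc3)cc2)cc1`, differs from compound 2 by hydrogen in place of phenyl on an aromatic carbon. None of the three measured steps concerns a phenyl leaving at this place, and none of them has a readable size, so nothing in the data points to a change beyond the scatter in this assay. Compound 4 is expected to stay at the limit, a step that the limit leaves unreadable from compound 2 to compound 4. Compound 4 is estimated at 15000 nM, with a range from 5000 nM to 50000 nM, and most probably the assay will again report only a limit.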

Compound 4, half-maximal effective concentration: > 10000 nM
Compound 4 gave a limit, no number; the forecaster's own chance of this, stated with the estimate: 85%; the middle value lies beyond the limit too.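

Compound 2 and compound 4 both sit at the same limit, so the step between them cannot be read and no new step follows: the limit of > 10000 nM in this assay, at which 4 of the 4 values shown sit.

The compounds shown leave open whether any change on the shared core gives a number in this assay, and how large any step in this series is.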